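This account rests on a few compounds, and the source may have more. Where it says the series, first, only, none or still open, it means among the compounds named here.

Measured compounds:
compound 1 `CCCCCCCCCCCCCC(=O)N[C@@H](CCC(=O)O)C(=O)Nc1ccn([C@H]2O[C@@H](CO)[C@H](O)[C@H]2O)c(=O)n1`, 502 nM
compound 2 `CCCCCCCCCC(=O)N[C@@H](CCC(=O)O)C(=O)Nc1ccn([C@H]2O[C@@H](CO)[C@H](O)[C@H]2O)c(=O)n1`, 1860 nM
compound 3 `CCCCCCCCCCCCCCCCCC(=O)N[C@@H](CCCNC(=N)N)C(=O)Nc1ccn([C@H]2O[C@@H](CO)[C@H](O)[C@H]2O)c(=O)n1`, 1700 nM

In a functional assay on HL-60 cells (Homo sapiens) for cytotoxicity, read by MTT assay, with a stated time of 48 h (a lower number here means a stronger inhibitor, a higher number a weaker inhibitor), compound 3 stands second highest of the three numbers. Its value and that of compound 2 lie within the scatter of each other, while compound 1 gives a number well below both.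

Compound 4 `CCCCCCCCCCCCCCCCCC(=O)N[C@@H](CCC(=O)O)C(=O)Nc1ccn([C@H]2O[C@@H](CO)[C@H](O)[C@H]2O)c(=O)n1` has not yet been measured in this assay. It differs from compound 3 in one place: a group of 3 heavy atoms (1 carbon, 2 oxygen; no ring) in place of a group of 5 heavy atoms (2 carbon, 3 nitrogen; no ring), on a saturated chain carbon, three bonds along the chain from an amide-type nitrogen and a carbonyl carbon. Within the data shown here, no measured pair shows this exchange on its own. Among the measured compounds shown here, the only measured step, a 3.7-fold higher number from compound 1 to compound 2 (0.57 log units; beyond the scatter), concerns the saturated chain, and it shows that a shorter chain goes with a higher number. Compound 4 carries the same long chain as compound 3 and the same carboxy side group as compound 1, so the comparison of compound 1 with compound 3 suggests that the group entering in compound 4 goes with a lower number than the group leaving. Compound 4 is therefore expected to give a lower number than compound 3, a step of about a 4.3-fold lower number from compound 3 to compound 4 (0.63 log units; beyond the scatter). The estimate for compound 4 in this assay is 400 nM, within a range from 150 nM to 1200 nM.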

Compound 4, half-maximal inhibitory concentration in the HL-60 assay: 1140 nM
Compound 4: middle estimate off by 2.9-fold (0.45 log units), on the low side; measured number inside the range.
By their numbers in the HL-60 assay, from the lowest: compound 1; then compounds 4, 3 and 2 (each within the scatter of the next).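

In the HL-60 assay, carboxy in place of the group of 5 heavy atoms, on a saturated chain carbon, gives a 1.5-fold lower number from compound 3 to compound 4 (0.17 log units; within the scatter), so the two side groups are not told apart at this position. The gap between compound 1 and compound 3 therefore goes with the chain and not the side group: butyl added gives a 2.3-fold higher number from compound 1 to compound 4 (0.36 log units; beyond the scatter), while octyl added gives a 1.6-fold lower number from compound 2 to compound 4 (0.21 log units; within the scatter), so compound 4 goes against the earlier link of a longer chain with a lower number. In a physicochemical assay for lipophilicity (on this read-out higher numbers stand for higher lipophilicity and lower numbers for lower lipophilicity), compound 3 gives 0.61 and compound 4 gives 0.5, and a number 0.11 log units lower from compound 3 to compound 4 (within the scatter) likewise separates neither side group.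

No evidence at hand accounts for these readings. Still open, on these data alone, is how an amine at this position, or a longer chain, would read in the HL-60 assay.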